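Amide chain variation on a glycosylthio-thiadiazole cytotoxicity series

The compounds below may be only part of what the source reports. "The series", "measured", "known", "first", "only" and "open" are said of these compounds alone.

Three amides built on one shared core have numbers in a functional assay on MDA-MB-231 cells (Homo sapiens) for cytotoxicity, read by MTT assay, with a stated time of 24 h; on this read-out higher numbers stand for weaker inhibition and lower numbers for stronger inhibition. Compound 1 `CCCCCCCC(=O)Nc1nnc(S[C@@H]2O[C@H](CO)[C@H](O)[C@H](O)[C@H]2O)s1` gives 30800 nM. Compound 2 `CCCCCCCC/C=C\CCCCCCCC(=O)Nc1nnc(S[C@@H]2O[C@H](CO)[C@H](O)[C@H](O)[C@H]2O)s1` gives 43600 nM. Compound 3 `CCCCCCCC/C=C\CCCCCCCCCCCC(=O)Nc1nnc(S[C@@H]2O[C@H](CO)[C@H](O)[C@H](O)[C@H]2O)s1` gives 70400 nM, the highest number of the three; its gap to compound 1 lies beyond the scatter, its gap to compound 2 within it. The difference between the cores of compound 2 and compound 3 is not broken down here.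

Compound 1 relates to compound 2 by hydrogen in place of dec-1-en-1-yl on a saturated chain carbon, seven bonds along the chain from a carbonyl carbon, and that step reads a 1.4-fold lower number from compound 2 to compound 1 (0.15 log units; within the scatter), within the scatter.

Compound 4 `CCCCCCCCCCCC(=O)Nc1nnc(S[C@@H]2O[C@H](CO)[C@H](O)[C@H](O)[C@H]2O)s1` is not yet measured in this assay. It relates to compound 3 by hydrogen in place of dec-1-en-1-yl on a saturated chain carbon, ten or more bonds along the chain from a carbonyl carbon. This is the same kind of change as from compound 2 to compound 1, but the place along the chain differs, as the two differences just described show. Because the earlier step of a 1.4-fold lower number from compound 2 to compound 1 (0.15 log units; within the scatter) was small, a small step is expected here as well, roughly a 1.8-fold lower number from compound 3 to compound 4 (0.25 log units; within the scatter). Compound 4 is therefore expected to give about 40000 nM in this assay, with a likely range from 20000 nM to 80000 nM.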

Compound 4, half-maximal inhibitory concentration: 32000 nM
For compound 4 the middle estimate is 1.3-fold (0.10 log units) above the measured one; measured number inside the range.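

Exchanging dec-1-en-1-yl for hydrogen gives steps of similar size on the two cores in this assay, although only the second step lies beyond the scatter: the same change on two cores in this assay, a 1.4-fold lower number (0.15 log units; within the scatter) from compound 2 to compound 1 and a 2.2-fold lower number (0.34 log units; beyond the scatter) from compound 3 to compound 4, 1.6-fold (0.19 log units) apart, within the scatter of two such steps. On these two pairs the change carries over, with a 2.2-fold lower number from compound 3 to compound 4 (0.34 log units; beyond the scatter) as its clearest reading, while a 1.4-fold lower number from compound 2 to compound 4 (0.13 log units; within the scatter) and a 1.0-fold higher number from compound 1 to compound 4 (0.02 log units; within the scatter) stay within the scatter, so exchanging dec-1-en-1-yl or hydrogen for butyl at that place gives no readable shift. Two pairs do not establish a rule for the series, and since the place of the change along the chain differs between them, they do not show whether that place matters.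

From the compounds shown here alone, a chain ending in an amine or a carboxylic acid remains open, as does a saturated chain longer than that of compound 4. Going by these compounds, whether the change carries over to cores beyond these two also remains open.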